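Chloro for Fluoro on an Aromatic Carbon: Expected Outcome

The source may hold more compounds than are shown below. What is called first, only, known or untested is meant among the compounds shown, and "the series" means these compounds.

Compound 1, `CC1=CC[C@H](C(C)(C)NC(=S)N/N=C/c2ccc(O)cc2)CC1`, in an ADME assay on Vero cells (Chlorocebus sabaeus) for inhibition, read by sulforhodamine B assay, with a stated time of 48 h (on this read-out higher numbers stand for weaker inhibition of growth and lower numbers for stronger inhibition of growth), gives > 100000 nM, which is a limit of the assay rather than a number.
Compound 2, `CC1=CC[C@H](C(C)(C)NC(=S)N/N=C/c2ccc(F)cc2)CC1`, in this assay gives > 100000 nM, also a limit of the assay.

Within the data shown here, compound 2 therefore stands at a limit in this assay, and the one further value shown is a limit as well, so no number places it against another compound. Among the measured compounds shown here, the single measured step, a step that the two limits leave unreadable from compound 1 to compound 2, is fluoro in place of hydroxy and cannot be read because of the limit of > 100000 nM in this assay, at which 2 of the 2 values shown sit. Compound 3, `CC1=CC[C@H](C(C)(C)NC(=S)N/N=C/c2ccc(Cl)cc2)CC1`, differs from compound 2 in that (chloro in place of fluoro on an aromatic carbon). The measured step concerns a different change and is itself unreadable, so it offers no direction for this one; what remains is that both known compounds sit at the limit. Compound 3 is thus estimated to stay near that limit, the step from compound 2 being expected as a step that the limit leaves unreadable from compound 2 to compound 3. The estimate for compound 3 is 150000 nM, expected between 50000 nM and 500000 nM.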

Compound 3, concentration for 50% growth inhibition: 70000 nM
Beside the measured number, compound 3's estimate is 2.1-fold (0.33 log units) above it; the range from low to high includes it.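

In this assay, among these compounds, compound 3 gives the only number among the three compounds that is not a limit, so this position on the aromatic ring can carry a group with a measurable value. Fluoro to chloro is an at least 1.4-fold lower number from compound 2 to compound 3 (0.15 log units; that floor lies within the scatter), and hydroxy to chloro is an at least 1.4-fold lower number from compound 1 to compound 3 (0.15 log units; that floor lies within the scatter). From the compounds shown here alone, each of these is only a floor that lies within the scatter, and the true size of each step stays unknown because one end of it is a limit: the limit of > 100000 nM in this assay, at which 2 of the 3 values shown sit.

The step between compound 1 and compound 2 still cannot be read. Going by these compounds, whether bromo, trifluoromethyl or an amine in the same place would give a lower number than chloro stays open.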